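A few compounds are considered here, and "the series" means these few. Any claim that something is new, unique, unknown or untested is made for them only; others in the source may bear on it.

Measured so far:
compound 1, `Nc1scc(-c2ccccc2F)c1C(=O)c1ccccc1` — in a functional assay on CHO cells for agonist activity at adenosine receptor A1 (Homo sapiens), read by fluorescence and ERK phosphorylation, with stated times of 30 min and 1.5 h, tested at 10 uM (on this read-out higher numbers stand for a stronger effect at the one concentration tested and lower numbers for a weaker effect), compound 1 gives 68%
compound 2, `Nc1scc(-c2cccc(Br)c2)c1C(=O)c1ccccc1` — in this assay compound 2 gives 76%

Compound 1 holds the lower of these two numbers, with compound 2 nearest to it; the step between them, a number 8 percentage points higher from compound 1 to compound 2 (within the scatter), is within the scatter, so the two values cannot be told apart and no order between them is claimed. That step involves a change at the ring carrying the fluorine, where compound 2 carries a bromine in its place.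

Compound 3, `Nc1scc(-c2ccccc2F)c1C(=O)c1ccc(Cl)cc1`, is the compound not yet measured. It differs from compound 1 by chloro in place of hydrogen on an aromatic carbon, leaving the fluorine-bearing ring untouched. Within the data shown here, no measured step bears on this particular change: the only step in hand, a number 8 percentage points higher from compound 1 to compound 2 (within the scatter), concerns a different part of the molecule and was itself within the scatter. With nothing pointing one way or the other, no movement beyond the scatter is expected in this assay. Compound 3 is therefore estimated at 68%, with a range from 45% to 88%, meaning an expected step of no change at the digits printed from compound 1 to compound 3 (within the scatter).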

Compound 3, a percentage reported as activity, at one concentration (the size of the read-out at that concentration, not a potency): 87%
The estimate for compound 3 lay 19 percentage points below the measured number; the range from low to high includes it.
By their numbers in this assay, from the lowest: compounds 1 and 2 (each within the scatter of the next); then compound 3.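

In this assay, chloro in place of hydrogen on the six-membered aromatic ring of carbon only, para to a large group, gives a number 19 percentage points higher from compound 1 to compound 3 (beyond the scatter). This is the first step in the compounds shown to pass beyond the scatter, whereas the earlier change on the fluorine-bearing ring, a number 8 percentage points higher from compound 1 to compound 2 (within the scatter), could not be told apart from no change, and it shows that the phenyl-to-4-chlorophenyl change on the other ring of the core of compound 1 can move this read-out at the one concentration tested. Nothing available accounts for this rise.

The compounds shown leave open whether the rise belongs to chloro itself or would also appear with another group at the same place, such as fluoro, methyl, methoxy or an amine, and whether chloro at another place on that ring would give a similar step. They also leave open whether the step would carry over to the core of compound 2 with its 3-bromophenyl group, and, with a single concentration as the read-out, how the potency of compound 3 compares with that of compound 1.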